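The compounds below may be only part of what the source reports. "The series", "measured", "known", "first", "only" and "open" are said of these compounds alone.

Compound 1 `CCCCCCCCn1cc(COC2(C(F)(F)F)Oc3ccccc3C=C2C(=O)OCC)nn1` was examined in a functional assay on DU-145 cells (Homo sapiens) for inhibition, read by MTT assay, with a stated time of 24 h; a higher number here means a weaker inhibitor, a lower number a stronger inhibitor. In this assay compound 1 gives only a limit, > 150000 nM, and not a measured number. Compound 2 `O=C(O)C1=Cc2ccccc2OC1(OCc1cc(-c2ccc(F)cc2F)no1)C(F)(F)F` shares the core of compound 1. In this assay compound 2 likewise returns only a limit, > 150000 nM. Compound 1 therefore stands at the limit itself, as summarised by the limit of > 150000 nM in this assay, at which 2 of the 2 values shown sit, and no measured number places it above or below any other compound. Compound 3 `CCOC(=O)C1=Cc2ccccc2OC1(OCc1cn(CC(=O)Nc2ccc(I)cc2Cl)nn1)C(F)(F)F` has not yet been tested in this assay. It differs from compound 1 by (2-chloro-4-iodophenyl)carbamoyl in place of heptyl on a saturated chain carbon bound to an aromatic nitrogen. Going by the values given here, no measured pair in this set shows how such a change reads in this assay, so the expected step is a number no higher from compound 1 to compound 3 (the limit leaves the size open), which is not expected to go beyond the scatter. Compound 3 is accordingly estimated at 150000 nM, within a range of 40000 nM to 500000 nM, and a limit rather than a number is the more likely report.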

Compound 3, half-maximal inhibitory concentration: 24400 nM
Compound 3: middle estimate off by 6.1-fold (0.79 log units), on the high side; measured number below the stated range.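

At the saturated chain carbon bound to an aromatic nitrogen, the group does change the reading in this assay: (2-chloro-4-iodophenyl)carbamoyl in place of heptyl gives an at least 6.1-fold lower number from compound 1 to compound 3 (0.78 log units; beyond the scatter). Compound 1 holds only a limit, so this step has a lower bound and no fixed size. Compound 3 is the only compound shown with a measured number rather than a limit: the limit of > 150000 nM in this assay, at which 2 of the 3 values shown sit.

The change brings in an aromatic ring, an amide, a chlorine and an iodine together, and the compounds shown do not separate what each of these contributes. Going by these compounds, how an unsubstituted phenylcarbamoyl, or a bromine in place of the iodine, would read at this position remains open.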